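Chloro for fluoro in two styrylsulfone series

A few compounds are considered here, and "the series" means these few. Any claim that something is new, unique, unknown or untested is made for them only; others in the source may bear on it.

Compound 1 `COc1cc(OC)c(/C=C/S(=O)(=O)Cc2ccc(F)c(N)c2)c(OC)c1` gives 2500 nM in a functional assay on DU-145 cells (Homo sapiens) for cytotoxicity, read by trypan blue exclusion, with a stated time of 96 h; on this read-out higher numbers stand for weaker inhibition and lower numbers for stronger inhibition. Compound 2 `COc1cc(OC)c(/C=C/S(=O)(=O)Cc2ccc(Cl)c(N)c2)c(OC)c1` gives 10 nM in this assay, and the change chloro in place of fluoro on an aromatic carbon yields a 250-fold lower number from compound 1 to compound 2 (2.40 log units; beyond the scatter). Compound 3 `COC(=O)C(Nc1cc(CS(=O)(=O)/C=C/c2c(OC)cc(OC)cc2OC)ccc1OC)c1ccc(F)cc1` gives 300 nM in this assay; the difference between its core and the core of compound 1 is not broken down here. Compound 4 `COC(=O)C(Nc1cc(CS(=O)(=O)/C=C/c2c(OC)cc(OC)cc2OC)ccc1OC)c1ccc(Cl)cc1` carries the change (chloro in place of fluoro on an aromatic carbon), the same kind of change as in compound 2 but not the same: there the carbon was also ortho to an amino group (1 heavy atom), here it is only para to a large group. Set beside the earlier step, a smaller step is expected from compound 3 to compound 4, a 3.0-fold lower number from compound 3 to compound 4 (0.48 log units; beyond the scatter), because the change a 250-fold lower number from compound 1 to compound 2 (2.40 log units; beyond the scatter) occurred at a differently surrounded position. Compound 4 is therefore estimated at 100 nM in this assay, between 20 nM and 600 nM.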

Compound 4, half-maximal inhibitory concentration: 400 nM
Beside the measured number, compound 4's estimate is 4.0-fold (0.60 log units) below it; the range from low to high includes it.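

In this assay chloro in place of fluoro gives a 1.3-fold higher number from compound 3 to compound 4 (0.12 log units; within the scatter) and so does not repeat the large step seen on the core of compound 1. The size of this change therefore did not carry from one core to the other in these two pairs: the same change on two cores in this assay, a 250-fold lower number (2.40 log units; beyond the scatter) from compound 1 to compound 2 and a 1.3-fold higher number (0.12 log units; within the scatter) from compound 3 to compound 4, 330-fold (2.52 log units) apart, beyond the scatter of two such steps. These pairs do not show which difference between the cores, or in the surroundings of the changed carbon, sets this gap, and two pairs establish no rule for the wider series.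

The compounds shown leave open how bromo or methyl in place of the halogen would behave on either core. They also leave open whether the result on the core of compound 3 would hold with a carboxylic acid in place of the methoxycarbonyl group.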